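The compounds below may be only part of what the source reports. "The series", "measured", "known", "first", "only" and "open" are said of these compounds alone.

Measured in a functional assay on HepG2 cells (Homo sapiens) for cytotoxicity, read by sulforhodamine B assay, with a stated time of 48 h; on this read-out higher numbers stand for weaker inhibition and lower numbers for stronger inhibition:
- compound 1, `CCOC(=O)c1c(-c2ccc(C)cc2)c(C#N)c(=O)n(/N=C(\C)c2ccc(NS(=O)(=O)c3ccc(Cl)cc3)cc2)c1N`: 8380 nM
- compound 2, `CCOC(=O)c1c(/C=C/c2ccccc2)c(C#N)c(=O)n(/N=C(\C)c2ccc(NS(=O)(=O)c3ccc(Cl)cc3)cc2)c1N`: 10700 nM

For the measured compounds named here, compound 2 stands within the scatter of compound 1, the only other number in this assay. Going by the values given here, the one measured step, a 1.3-fold higher number from compound 1 to compound 2 (0.11 log units; within the scatter), is itself within the scatter.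

Compound 3, `CCOC(=O)c1c(-c2ccccc2Cl)c(C#N)c(=O)n(/N=C(\C)c2ccc(NS(=O)(=O)c3ccc(Cl)cc3)cc2)c1N`, carries 2-chlorophenyl in place of 2-phenylethenyl on an aromatic carbon. Among the compounds with values here, the single measured step swaps the group at this same place and leaves the number essentially unchanged, so no step beyond the scatter is expected here either.

Compound 3 is therefore estimated at 9000 nM in this assay, with a range of 4000 nM to 20000 nM; this expectation corresponds to a 1.2-fold lower number from compound 2 to compound 3 (0.08 log units; within the scatter).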

Compound 3, half-maximal inhibitory concentration: 11400 nM
Estimate against measurement, compound 3: 1.3-fold (0.10 log units) below; the range from low to high includes it.
By their numbers in this assay, from the lowest: compounds 1, 2 and 3 (each within the scatter of the next).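

Replacing the group on the aromatic carbon opposite the ring nitrogen with 2-chlorophenyl gives a 1.1-fold higher number from compound 2 to compound 3 (0.03 log units; within the scatter) and a 1.4-fold higher number from compound 1 to compound 3 (0.13 log units; within the scatter) in this assay for this series. Three different groups at this place, 4-methylphenyl, 2-phenylethenyl and 2-chlorophenyl, now stand within the scatter of one another, so a chlorine on the phenyl ring brings no separation from the other two.

From the compounds shown here alone, whether an amine, a carboxylic acid or a longer alkyl chain at this place would stay within the scatter remains open. No evidence on hand accounts for this flat result.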